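From dimethoxyphenyl to trimethoxyphenyl: a step with little guidance

The compounds below may be only part of what the source reports. "The series", "measured", "known", "first", "only" and "open" are said of these compounds alone.

Measured so far in a functional assay on A549 cells (Homo sapiens) for cytotoxicity, read by MTT assay, with a stated time of 72 h; on this read-out lower numbers stand for stronger inhibition and higher numbers for weaker inhibition:
- Compound 1 `COc1cc2ncnc(Nc3ccc(F)c(Cl)c3)c2cc1NC(=O)/C=C/c1ccc(F)cc1Cl`: "not active" (no number reported)
- Compound 2 `COc1ccc(/C=C/C(=O)Nc2cc3c(Nc4ccc(F)c(Cl)c4)ncnc3cc2OC)c(OC)c1`: 33300 nM

Among the measured compounds shown here, compound 2 holds the only number in this small set, while compound 1 was reported without one. The two therefore cannot be placed on a shared numerical scale, and no trend can be read from them.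

The next compound to be tested is compound 3 `COc1cc2ncnc(Nc3ccc(F)c(Cl)c3)c2cc1NC(=O)/C=C/c1cc(OC)c(OC)c(OC)c1`. It keeps the shared core of compound 2 and changes in one place: 3,4,5-trimethoxyphenyl in place of 2,4-dimethoxyphenyl on a double-bonded chain carbon bound to a double-bonded chain carbon. In words, this puts 3,4,5-trimethoxyphenyl in place of 2,4-dimethoxyphenyl on a double-bonded chain carbon bound to a double-bonded chain carbon.

For the measured compounds named here, no measured pair shows what a change at this place does in this assay. Going by the values given here, the only numerical anchor is compound 2 at 33300 nM, so the expected step, a 1.1-fold lower number from compound 2 to compound 3 (0.05 log units; within the scatter), is none beyond the usual scatter, with no direction favoured. A report without a number also remains possible, as seen for compound 1. For compound 3, the estimated value is 30000 nM, with an expected range from 10000 nM to 90000 nM.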

Compound 3, half-maximal inhibitory concentration: "not active" (no number reported)
The entry for compound 3 holds no number; the estimate stays without a comparison.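

Among the compounds shown here, compound 3, like compound 1, was reported in this assay without a number, so no step from compound 2 to compound 3 can be read. No measured information on hand explains this result. The compounds shown leave open how 3,4,5-trimethoxyphenyl in place of 2,4-dimethoxyphenyl changes the number in this assay.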